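From cyano to 3-hydroxypropyl: a stability estimate

A few compounds are considered here, and "the series" means these few. Any claim that something is new, unique, unknown or untested is made for them only; others in the source may bear on it.

Results in an ADME assay on microsomes from liver (Homo sapiens) for metabolic stability, with a stated time of 10 min; a higher number here means that more of the compound is left, a lower number that less of the compound is left:
- compound 1 `Fc1cc(-c2ccccc2C(F)(F)F)cc2nc(C3=NOC4(CCCCC4)C3)[nH]c12`: 46%
- compound 2 `FC(F)(F)c1ccccc1-c1cc(Cl)c2[nH]c(C3=NOC4(CCCCC4)C3)nc2c1`: 92%
- compound 3 `N#Cc1cc(-c2ccccc2C(F)(F)F)cc2nc(C3=NOC4(CCCCC4)C3)[nH]c12`: 68%

Compound 3 stands in the middle of these three: a number 22 percentage points higher from compound 1 to compound 3 (beyond the scatter), and a number 24 percentage points lower from compound 2 to compound 3 (beyond the scatter). Compound 4 `OCCCc1cc(-c2ccccc2C(F)(F)F)cc2nc(C3=NOC4(CCCCC4)C3)[nH]c12` has 3-hydroxypropyl in place of cyano on an aromatic carbon. Earlier swaps at this carbon gave modest to large steps, the largest being a number 46 percentage points higher from compound 1 to compound 2 (beyond the scatter). Among the measured compounds shown here, none of the measured compounds carries a chain, so the direction is a judgement call, and a modest fall in this assay is expected. The estimated change is a number 16 percentage points lower from compound 3 to compound 4 (beyond the scatter). Compound 4 is estimated at 52%, with an expected range of 28% to 78%.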

Compound 4, percent of the compound remaining: 57%
Estimate against measurement, compound 4: 5 percentage points below; the measured number falls inside the stated range.
By their numbers in this assay, from the lowest: compound 1; then compound 4; then compound 3; then compound 2.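

At this aromatic carbon, 3-hydroxypropyl, the only chain so far, lands within the span of the smaller groups in this assay: it sits above fluoro (a number 11 percentage points higher from compound 1 to compound 4 (beyond the scatter)) and below cyano (a number 11 percentage points lower from compound 3 to compound 4 (beyond the scatter)) and chloro (a number 35 percentage points lower from compound 2 to compound 4 (beyond the scatter)). So the position tolerates a longer group carrying a hydrogen-bond donor, while chloro stays highest of the four. Nothing available explains this order.

As far as these compounds go, what a plain propyl, a longer chain or an amine at this carbon would give stays open. So does whether the hydroxyl or the carbon chain accounts for these steps.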